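Lengthening the linker from compound 2 to compound 3

The source may report more compounds than this note shows. Statements on the series, on what has been measured and on what is new or still open speak of the compounds shown alone.

Compound 1, `COc1c(OCCCCN2CCN(C)CC2)cc(O)c2c(=O)cc(-c3ccc(C(F)(F)F)cc3)oc12`, gives 2890 nM in a functional assay on A549 cells (Homo sapiens) for cytotoxicity, read by MTT assay, with a stated time of 72 h; a higher number here means a weaker inhibitor, a lower number a stronger inhibitor.
Compound 2, `CN1CCN(CCCOc2c(OCc3ccccc3)cc(O)c3c(=O)cc(-c4ccccc4)oc23)CC1`, gives 3940 nM in this assay.

These two numbers are all that is known. Compound 2 stands close to compound 1 in this assay; the gap between them is within the usual scatter of such measurements, so no order can be read from it. Compound 3, `CN1CCN(CCCCOc2c(OCc3ccccc3)cc(O)c3c(=O)cc(-c4ccccc4)oc23)CC1`, has not yet been measured in this assay. It differs from compound 2 in one place: (4-methylpiperazin-1-yl)methyl in place of 4-methylpiperazin-1-yl on a saturated chain carbon, three bonds along the chain from an oxygen on an aromatic ring. Going by the values given here, no measured pair shows this exact change, so the size of its step is unknown. The two measured numbers lie near each other, and the change is a small one in a chain, so the step is expected to be small in either direction and not clearly beyond the scatter. For compound 3 the expected value in this assay is 3300 nM, within the range 1500 nM to 7500 nM, which means an expected step of a 1.2-fold lower number from compound 2 to compound 3 (0.08 log units; within the scatter).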

Compound 3, half-maximal inhibitory concentration: 2910 nM
Estimate against measurement, compound 3: 1.1-fold (0.05 log units) above, within the range that was stated.
By their numbers in this assay, from the lowest: compounds 1, 3 and 2 (each within the scatter of the next).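

Going by these compounds alone, the earlier compounds offered no pair differing in one place, so this is the first reading of the chain on its own: in this assay, (4-methylpiperazin-1-yl)methyl in place of 4-methylpiperazin-1-yl on this saturated chain carbon gives a 1.4-fold lower number from compound 2 to compound 3 (0.13 log units; within the scatter) for the change. On this single pair, the 3-(4-methylpiperazin-1-yl)propyl and 4-(4-methylpiperazin-1-yl)butyl chains cannot be told apart in this read-out. The compounds shown carry no measurement that would explain this result.

On these data alone, whether a still longer chain, such as 5-(4-methylpiperazin-1-yl)pentyl, or a morpholine or dimethylamine in place of the 4-methylpiperazine at the chain end would read differently remains open. So does whether the same chain change would give a similar step on the core of compound 1.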